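Chloro in Place of Methoxy: From Compound 3 to Compound 4

The compounds below may be only part of what the source reports. "The series", "measured", "known", "first", "only" and "open" are said of these compounds alone.

Three compounds built on one shared core differ only in the group on a nitrogen on an aromatic ring. Compound 1 `CCS(=O)(=O)Nc1cc(-c2ccc3ncnc(Nc4cccc(F)c4)c3c2)cnc1OC` gives 8020 nM in a functional assay on MCF7 cells (Homo sapiens) for cytotoxicity, read by sulforhodamine B assay, with a stated time of 72 h; a higher number here means a weaker inhibitor, a lower number a stronger inhibitor. Compound 2 `CCS(=O)(=O)Nc1cc(-c2ccc3ncnc(Nc4ccc(F)cc4F)c3c2)cnc1OC` gives 1610 nM, and compound 3 `CCS(=O)(=O)Nc1cc(-c2ccc3ncnc(Nc4ccc(OC)c(OC)c4)c3c2)cnc1OC` gives 2430 nM, the second highest of the three numbers. The steps of a 5.0-fold lower number from compound 1 to compound 2 (0.70 log units; beyond the scatter) and a 3.3-fold lower number from compound 1 to compound 3 (0.52 log units; beyond the scatter) lie beyond the scatter, whereas a 1.5-fold higher number from compound 2 to compound 3 (0.18 log units; within the scatter) does not. Compound 4 `CCS(=O)(=O)Nc1cc(-c2ccc3ncnc(Nc4ccc(OC)c(Cl)c4)c3c2)cnc1OC` differs from compound 3 by chloro in place of methoxy on an aromatic carbon. Among the compounds with values here, no measured step exchanges a methoxy for a chloro; the steps seen so far swap the whole phenyl group and reach at most modest size. A step of a 1.2-fold lower number from compound 3 to compound 4 (0.08 log units; within the scatter) is therefore expected, within the scatter. Compound 4 is estimated at 2000 nM, with a range from 800 nM to 5000 nM.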

Compound 4, half-maximal inhibitory concentration: 3320 nM
Estimate against measurement, compound 4: 1.7-fold (0.22 log units) below; the range from low to high includes it.
By their numbers in this assay, from the lowest: compounds 2, 3 and 4 (each within the scatter of the next, the first and the last beyond it); then compound 1.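

Within the data shown here, on the aromatic carbon ortho to a methoxy group, chloro in place of methoxy gives a 1.4-fold higher number from compound 3 to compound 4 (0.14 log units; within the scatter) in this assay, the first exchange of a single substituent on this phenyl group, and it leaves compound 3 and compound 4 indistinguishable. Even so, the 3-chloro-4-methoxyphenyl group stands apart from both fluorinated groups, with a 2.1-fold higher number from compound 2 to compound 4 (0.31 log units; beyond the scatter) and a 2.4-fold lower number from compound 1 to compound 4 (0.38 log units; beyond the scatter), whereas compound 3 lay within the scatter of compound 2. No evidence is available to explain these numbers. The compounds shown leave open whether an amine, a hydroxy or a longer alkoxy chain at this position would depart from methoxy and chloro. They also leave open whether chloro in place of methoxy gives so small a step with other groups at the neighbouring methoxy position.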